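The source may hold more compounds than are shown below. What is called first, only, known or untested is meant among the compounds shown, and "the series" means these compounds.

Within the data shown here, compound 2 `O=C(C/C=C/c1ccccc1)Nc1nc2ccccc2c(=O)s1` gives 361 nM in an assay on mitochondria (strain Sprague-Dawley) for inhibition of Amine oxidase [flavin-containing] B (Rattus norvegicus), read by fluorescence and Amplex Red, with stated times of 30 min and 45 min (a lower number here means a stronger inhibitor, a higher number a weaker inhibitor), the lowest of the two numbers so far; its nearest neighbour, compound 1 `COc1cccc(/C=C/CC(=O)Nc2nc3ccccc3c(=O)s2)c1`, gives 2020 nM. Compound 3 `O=C(C/C=C/c1ccc(Cl)c(Cl)c1)Nc1nc2ccccc2c(=O)s1` carries 3,4-dichlorophenyl in place of phenyl on a double-bonded chain carbon bound to a double-bonded chain carbon. Among the measured compounds shown here, the only measured step, a 5.6-fold lower number from compound 1 to compound 2 (0.75 log units; beyond the scatter), concerns a different substituent on the same ring and runs in the sense of removal rather than addition, so it offers only indirect guidance for this change. For compound 3 a step of a 1.4-fold lower number from compound 2 to compound 3 (0.16 log units; within the scatter) in this assay is expected, at most modest. The expected value for compound 3 is 250 nM, with the range 60 nM to 1200 nM.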

Compound 3, half-maximal inhibitory concentration: 4640 nM
Estimate against measurement, compound 3: 19-fold (1.27 log units) below, outside the stated range (above it).
By their numbers in this assay, from the lowest: compound 2; then compound 1; then compound 3.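

In this assay, the phenyl on the double-bonded chain carbon does not tolerate every addition: 3,4-dichlorophenyl in its place gives a 13-fold higher number from compound 2 to compound 3 (1.11 log units; beyond the scatter) and is the first change shown to cost this much. Replacing 3-methoxyphenyl with 3,4-dichlorophenyl gives a 2.3-fold higher number from compound 1 to compound 3 (0.36 log units; beyond the scatter), so both substituted rings shown lie on the weaker side of the unsubstituted phenyl. No available evidence bears on the cause of this loss.

From the compounds shown here alone, whether one chlorine alone carries the loss remains open. So does the outcome with a smaller group on the ring, such as fluorine or hydroxyl.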